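Trimming the Octyl Chain of Compound 1

The compounds below may be only part of what the source reports. "The series", "measured", "known", "first", "only" and "open" are said of these compounds alone.

In a functional assay on MDA-MB-231 cells (Homo sapiens) for cytotoxicity, read by sulforhodamine B assay, with a stated time of 72 h (a lower number here means a stronger inhibitor of growth, a higher number a weaker inhibitor of growth), the three measured compounds give:
Compound 1 `CCCCCCCCC(=O)N1c2ccccc2CCC1C(=O)Nc1ccccc1C(F)(F)F`: 3350 nM
Compound 2 `CCCCCCCCC(=O)N1c2ccccc2CCC1C(=O)Nc1ccccc1O`: 54300 nM
Compound 3 `O=C(Nc1cc(C(F)(F)F)cc(C(F)(F)F)c1)C1CCc2ccccc2N1`: 8270 nM

Compound 1 stands lowest of the three. Compound 3 sits nearest to it, and compound 2, reached by a 16-fold higher number from compound 1 to compound 2 (1.21 log units; beyond the scatter), lies furthest away. Compound 4 `CC(=O)N1c2ccccc2CCC1C(=O)Nc1ccccc1C(F)(F)F` differs from compound 1 by hydrogen in place of heptyl on a saturated chain carbon bound to a carbonyl carbon. Going by the values given here, no measured step touches this chain: the one known step alters the aromatic substituent, and compound 3, which carries no acyl group at all, also bears a different aryl group, so its gap to compound 1 cannot be split into two parts. With no direct guide, the expectation for compound 4 stays close to compound 1 with a wide range. Compound 4 is therefore expected at 6000 nM, between 1500 nM and 25000 nM, an estimated step of a 1.8-fold higher number from compound 1 to compound 4 (0.25 log units; within the scatter) that may or may not exceed the scatter.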

Compound 4, concentration for 50% growth inhibition: > 80000 nM
Compound 4 ended at the assay's limit; the forecaster's own chance of this, stated with the estimate: 5%; middle value at least 13-fold (1.12 log units) away from the limit.
By their numbers in this assay, from the lowest: compound 1; then compound 3; then compound 2. At a limit, above all of these: compound 4.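

Putting hydrogen in place of heptyl on the saturated chain carbon bound to the carbonyl carbon, which turns octyl into methyl, gives an at least 23-fold higher number from compound 1 to compound 4 (1.37 log units; beyond the scatter). Compound 4 reads at a limit of this assay, not at a number: the limit of > 80000 nM in this assay, at which 1 of the 4 values shown sits.

With the rest of compound 1 unchanged, this chain alone separates a measurable value from a limit. The compounds shown leave open how the number changes at chain lengths between octyl and methyl. A butyl chain, a dodecyl chain or an amine at the end of the chain would help show whether chain length alone counts.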